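Replacing Isopropyl with Phenethyl on the Amine-Bearing Chain

A few compounds are considered here, and "the series" means these few. Any claim that something is new, unique, unknown or untested is made for them only; others in the source may bear on it.

Three compounds have been measured in an assay on HEK293 cells for binding affinity to Gonadotropin-releasing hormone receptor (Homo sapiens), read by radioligand binding; a lower number here means a stronger inhibitor, a higher number a weaker inhibitor:

Compound 1, `CN[C@H](CC(C)C)Cn1c(=O)c(-c2cccc(OC)c2F)c(C)n(Cc2c(F)cccc2F)c1=O`, gives 1.2 nM.
Compound 2, `COc1cccc(-c2c(C)n(Cc3c(F)cccc3F)c(=O)n(C[C@@H](N)CC(C)C)c2=O)c1F`, gives 39 nM.
Compound 3, `COc1cccc(-c2c(C)n(Cc3c(F)cccc3F)c(=O)n(C[C@@H](N)C(C)C)c2=O)c1F`, gives 973 nM.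

Compound 3 stands highest of the three: a 25-fold higher number from compound 2 to compound 3 (1.40 log units; beyond the scatter), and an 810-fold higher number from compound 1 to compound 3 (2.91 log units; beyond the scatter). Compound 4, `COc1cccc(-c2c(C)n(Cc3c(F)cccc3F)c(=O)n(C[C@@H](N)CCc3ccccc3)c2=O)c1F`, is the next step from compound 3. The change is phenethyl in place of isopropyl on a saturated chain carbon bound to an amine nitrogen and a saturated chain carbon.

The step that bears on it is the one at the same place, a 25-fold higher number from compound 2 to compound 3 (1.40 log units; beyond the scatter), where exchanging isobutyl for isopropyl raised the number strongly. Compound 4 again replaces isopropyl at that place, so a clearly lower number is expected for compound 4, a 19-fold lower number from compound 3 to compound 4 (1.29 log units; beyond the scatter). The estimate for compound 4 is 50 nM, with a range from 8 nM to 300 nM.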

Compound 4, inhibition constant: 965 nM
Compound 4: the middle estimate sits 19-fold (1.29 log units) below what was measured, and the stated range ends below it.
By their numbers in this assay, from the lowest: compound 1; then compound 2; then compounds 4 and 3 (each within the scatter of the next).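

In this assay, phenethyl and isopropyl cannot be told apart at this place (a 1.0-fold lower number from compound 3 to compound 4 (0.00 log units; within the scatter)), so adding a six-membered aromatic ring to the chain gives no measurable gain. Isobutyl still gives a clearly lower number than phenethyl (a 25-fold higher number from compound 2 to compound 4 (1.39 log units; beyond the scatter)), and the 3-methyl-1-(methylamino)butyl chain of compound 1 gives a far lower one (an 800-fold higher number from compound 1 to compound 4 (2.91 log units; beyond the scatter)), showing that a larger group alone does not bring the number down. No measured evidence here explains this result.

Still open, going by these compounds, is how a benzyl group or a shorter cyclopropylmethyl group would read at this place. Also open, on these data alone, is whether a methyl group on the amine nitrogen of compound 4 would lower its number.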